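Trimethylphenyl in Place of Trifluorophenyl: Compound 4 Expected

The compounds below may be only part of what the source reports. "The series", "measured", "known", "first", "only" and "open" are said of these compounds alone.

Compound 1: `Cc1cc(C)c(NC(=O)N(Cc2ccc(-c3nnc(C)o3)cc2)C2CCCCCC2)c(C)c1`, 27 nM
Compound 2: `Cc1cc(C)c(NC(=O)N(Cc2ccc(N3CCN(C)CC3)cc2)C2CCCCCC2)c(C)c1`, 57 nM
Compound 3: `O=C(Nc1c(F)cc(F)cc1F)N(Cc1ccc(-c2ccsc2)cc1)C1CCCCCC1`, 23 nM

In an assay on microsomes from intestine for inhibition of acyl-CoA:cholesterol acyltransferase (Oryctolagus cuniculus) (a lower number here means a stronger inhibitor, a higher number a weaker inhibitor), compound 3 gives the lowest of the three numbers. Its nearest neighbour is compound 1, whose number lies within the scatter of it, so no order between these two can be claimed; compound 2 stands further away, beyond the scatter. Compound 4 has the structure `Cc1cc(C)c(NC(=O)N(Cc2ccc(-c3ccsc3)cc2)C2CCCCCC2)c(C)c1`; it differs from compound 3 by 2,4,6-trimethylphenyl in place of 2,4,6-trifluorophenyl on an amide-type nitrogen.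

Among the compounds with values here, the only step measured between single-change neighbours, a 2.1-fold higher number from compound 1 to compound 2 (0.32 log units; beyond the scatter), concerns a group on an aromatic carbon at the other end of the shared core and does not touch the change under consideration. Within the data shown here, no measured pair isolates the aryl on the amide-type nitrogen. What the numbers do show is that compound 1 and compound 2, both carrying the 2,4,6-trimethylphenyl, sit within or close to the range of compound 3, which carries the 2,4,6-trifluorophenyl, though they also differ elsewhere. On that basis no step beyond the scatter is expected for compound 4 in this assay, with a 1.3-fold higher number from compound 3 to compound 4 (0.12 log units; within the scatter). Compound 4 is therefore estimated at 30 nM, within 12 nM to 75 nM.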

Compound 4, half-maximal inhibitory concentration: 19 nM
For compound 4 the middle estimate is 1.6-fold (0.20 log units) above the measured one; measured number inside the range.
By their numbers in this assay, from the lowest: compounds 4, 3 and 1 (each within the scatter of the next); then compound 2.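

In this assay, within the data shown here, the pair compound 3 and compound 4 isolates the aryl on the amide-type nitrogen for the first time, and it gives a 1.2-fold lower number from compound 3 to compound 4 (0.08 log units; within the scatter) so that 2,4,6-trimethylphenyl and 2,4,6-trifluorophenyl cannot be ordered here, at least with thiophen-3-yl on the aromatic carbon. With 2,4,6-trimethylphenyl held fixed, the group on the aromatic carbon now reads more fully: thiophen-3-yl in place of 4-methylpiperazin-1-yl gives a 3.0-fold lower number from compound 2 to compound 4 (0.48 log units; beyond the scatter) while thiophen-3-yl in place of 5-methyl-1,3,4-oxadiazol-2-yl gives a 1.4-fold lower number from compound 1 to compound 4 (0.15 log units; within the scatter) and so, among these three groups, only 4-methylpiperazin-1-yl stands apart. No measurement shown here accounts for any of these steps.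

Whether the aryl change would stay within the scatter with 4-methylpiperazin-1-yl or 5-methyl-1,3,4-oxadiazol-2-yl on the aromatic carbon remains open, since only one such pair is shown. Also open is what an aryl on the amide-type nitrogen carrying a carboxylic acid or an amine, or a phenyl with no substituents at all, would do in this assay given that both aryl groups shown here carry three substituents.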